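The source may hold more compounds than are shown below. What is called first, only, known or untested is meant among the compounds shown, and "the series" means these compounds.

Compound 1 `Cc1cc(NC(=O)Nc2ccc(Cl)c(Cl)c2)c2ccccc2n1`, compound 2 `Cc1cc(NC(=O)Nc2cccc([N+](=O)[O-])c2)c2ccccc2n1` and compound 3 `Cc1cc(NC(=O)Nc2ccc(N(C)C)cc2)c2ccccc2n1` share one core and differ in the groups they carry on an aromatic ring. All three were tested in an ADME assay on HEK293 cells (Homo sapiens) for cytotoxicity, with a stated time of 72 h; a higher number here means that more compound is needed for the effect, a lower number that less compound is needed. Compound 1 gives > 25000 nM, which is a limit of the assay and not a number. Compound 2 gives > 25000 nM, again a limit. Compound 3 stands at > 25000 nM, also a limit. The three results therefore tell one simple story: the limit of > 25000 nM in this assay, at which 3 of the 3 values shown sit.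

Compound 4 `Cc1cc(NC(=O)Nc2ccc(SC(F)(F)F)cc2)c2ccccc2n1` has not yet been measured. It keeps the core of compound 3 and changes one group, with (trifluoromethyl)sulfanyl in place of dimethylamino on an aromatic carbon. Among the measured compounds shown here, no two measured compounds differ in just one place, so no measured step can guide the size of this change. For the measured compounds named here, the only guide is that three different sets of groups all end at the same limit. The direct partner of compound 4 is compound 3. Compound 3 gives > 25000 nM, again a limit. In this assay no change beyond the usual scatter is expected, in either direction, so the estimated step is small: a number no higher from compound 3 to compound 4 (the limit leaves the size open). The assay will most likely report only a limit again. For compound 4 the expected value is 25000 nM, with an estimated range from 8000 nM to 50000 nM.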

Compound 4, half-maximal effective concentration: 13000 nM
Compound 4: middle estimate off by 1.9-fold (0.28 log units), on the high side; the measured number falls inside the stated range.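

In this assay, compound 4 is the only compound shown that gives a number and not a limit, which shows that a change at this place on the aromatic ring can bring the read-out within the measurable range. Swapping dimethylamino for (trifluoromethyl)sulfanyl gives an at least 1.9-fold lower number from compound 3 to compound 4 (0.28 log units; that floor lies within the scatter), and the true size of this step stays unknown, as the starting value is only a limit. The earlier compounds could show only a shared limit, and compound 4 is the single exception to it: the limit of > 25000 nM in this assay, at which 3 of the 4 values shown sit.

The compounds shown leave open what a carboxylic acid, an amine other than dimethylamino or a longer chain would give at this same place, and so whether other groups would also yield a number in this assay. With a single measured number, they also cannot tell which part of (trifluoromethyl)sulfanyl, its sulfur or its three fluorine atoms, goes with the result, or whether the same swap would have a similar effect on a different core.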